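Fluoro for chloro on the benzyl ring

The source may hold more compounds than are shown below. What is called first, only, known or untested is meant among the compounds shown, and "the series" means these compounds.

Within the data shown here, compound 2 `CC1=C(C(=O)Nc2ccc([N+](=O)[O-])cc2)C(c2ccc(Br)cc2)N=C(SCc2ccc(Cl)cc2)N1` gives 39.2% in a functional assay on the whole organism (artery, strain albino) with Rattus norvegicus as the target, with a stated time of 360 min, at a dose of 10 mg/kg by the oral route (a lower number here means less inhibition, a higher number more inhibition at the dose given (going by the name of the read-out)), the higher of the two numbers measured so far, while compound 1 `CC1=C(C(=O)Nc2ccc([N+](=O)[O-])cc2)C(c2ccc(Br)cc2)N=C(SCc2ccccc2Cl)N1` gives 13.9%. Among the measured compounds shown here, the only measured step, a number 25.3 percentage points higher from compound 1 to compound 2 (beyond the scatter), concerns 4-chlorophenyl in place of 2-chlorophenyl, not an exchange of one halogen for another. Compound 3 `CC1=C(C(=O)Nc2ccc([N+](=O)[O-])cc2)C(c2ccc(Br)cc2)N=C(SCc2ccc(F)cc2)N1` differs from compound 2 by fluoro in place of chloro on an aromatic carbon. For the measured compounds named here, no measured step bears directly on this exchange, so no change beyond the scatter is expected in this assay: a number 4.2 percentage points lower from compound 2 to compound 3 (within the scatter). Compound 3 is therefore estimated at 35%, with a range from 15% to 55%.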

Compound 3, a percentage reported as inhibition, in the whole organism at one dose (the size of the read-out at that dose, not a potency): 38.7%
Compound 3: the middle estimate sits 3.7 percentage points below what was measured; the measured number falls inside the stated range.
By their numbers in this assay, from the lowest: compound 1; then compounds 3 and 2 (each within the scatter of the next).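

In this assay, fluoro in place of chloro on the benzyl ring gives a number 0.5 percentage points lower from compound 2 to compound 3 (within the scatter), so the two halogens are not told apart at this place. The step of a number 24.8 percentage points higher from compound 1 to compound 3 (beyond the scatter) shows that the rise seen with 4-chlorophenyl over 2-chlorophenyl also holds for 4-fluorophenyl. No measurement on hand accounts for either result.

The compounds shown leave open whether a 4-methoxy group or a 4-amino group would match the halogens here. They also leave open whether 2-fluorophenyl would stay as low as 2-chlorophenyl.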